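The source may report more compounds than this note shows. Statements on the series, on what has been measured and on what is new or still open speak of the compounds shown alone.

Of the compounds shown here, three with a shared core have been tested in a functional assay on cells (Platelet, Homo sapiens) for inhibition; a lower number here means a stronger inhibitor, a higher number a weaker inhibitor. Compound 1 `CCOC(=O)c1ccc(-c2nn(Cc3cccc(Cl)c3)c3ccccc23)cc1` gives only a limit there, > 10000 nM. Compound 2 `CCOC(=O)c1ccc(-c2nn(Cc3cccc(F)c3)c3ccccc23)cc1` likewise gives only a limit, > 10000 nM. Compound 3 `CCOC(=O)c1ccc(-c2nn(-c3ccco3)c3ccccc23)cc1` also gives only a limit, > 10000 nM. The steps a step that the two limits leave unreadable from compound 1 to compound 2, a step that the two limits leave unreadable from compound 1 to compound 3 and a step that the two limits leave unreadable from compound 2 to compound 3 therefore cannot be read, since (the limit of > 10000 nM in this assay, at which 3 of the 3 values shown sit). Compound 4 `CCOC(=O)c1ccc(-c2nn(-c3ccccc3)c3ccccc23)cc1` differs from compound 3 in one place: phenyl in place of furan-2-yl on an aromatic nitrogen. For the measured compounds named here, none of the measured steps has a readable size, so they give no direction for this change in this assay . Compound 4 is expected to remain at a limit, estimated near 15000 nM with a range from 8000 nM to 40000 nM. That estimate means a step that the limit leaves unreadable from compound 3 to compound 4, which would be expected to stay within the scatter .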

Compound 4, half-maximal inhibitory concentration: > 10000 nM
Compound 4 ended at the assay's limit; the forecaster's own chance of this, stated with the estimate: 85%; the middle value is on the limit's open side.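

For the compounds shown here, compound 4 also gives only a limit in this assay, so no step among compound 1, compound 2, compound 3 and compound 4 can be read: the limit of > 10000 nM in this assay, at which 4 of the 4 values shown sit. The compounds shown leave open whether any group on the aromatic nitrogen gives measurable inhibition.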